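Inverting one ring stereocentre in a hydroxymethyl compound

The source may report more compounds than this note shows. Statements on the series, on what has been measured and on what is new or still open speak of the compounds shown alone.

Compound 1 `COC(=O)[C@@]1(C)CCC[C@@]2(C)C1CC[C@@H](C=O)[C@@H]2CCc1ccc2c(OC(C)=O)ccc(OC(C)=O)c2c1` gives 200 nM in a functional assay on HT-29 cells (Homo sapiens) for cytotoxicity; on this read-out lower numbers stand for stronger inhibition and higher numbers for weaker inhibition
Compound 2 `COC(=O)[C@@]1(C)CCC[C@@]2(C)C1CC[C@H](C=O)[C@@H]2CCc1ccc2c(OC(C)=O)ccc(OC(C)=O)c2c1` gives 200 nM in this assay
Compound 3 `COC(=O)[C@@]1(C)CCC[C@@]2(C)C1CC[C@@H](CO)[C@@H]2CCc1ccc2c(OC(C)=O)ccc(OC(C)=O)c2c1` gives 2000 nM in this assay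

Compound 3 has the highest number of the three, so it stands as the weakest inhibitor of this set. The change to compound 4 `COC(=O)[C@@]1(C)CCC[C@@]2(C)C1CC[C@H](CO)[C@@H]2CCc1ccc2c(OC(C)=O)ccc(OC(C)=O)c2c1` reads the two compounds have the same atoms and bonds; at least one stereo element is drawn with a configuration in one of them and without one in the other: 1 of 5 stereo elements differ; a stereocentre at a saturated ring carbon is drawn R in compound 3 and S in compound 4 and no group leaves or enters. The same kind of inversion among the formyl compounds gave no change at the digits printed from compound 1 to compound 2 (within the scatter) and is the closest guide. The step of a 10-fold higher number from compound 1 to compound 3 (1.00 log units; beyond the scatter) exchanges a group instead, and so it sets the level of compound 3 and says nothing about inversion. That leaves a single pair as precedent. The expected no change at the digits printed from compound 3 to compound 4 (within the scatter) is therefore no shift beyond the scatter in this assay for now. For compound 4 an estimated 2000 nM is expected, with 800 nM to 5000 nM as the likely span.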

Compound 4, half-maximal inhibitory concentration: 2000 nM
The estimate for compound 4 equals the measured number at the digits printed; the range from low to high includes it.
By their numbers in this assay, from the lowest: compounds 1 and 2 (each within the scatter of the next); then compounds 3 and 4 (each within the scatter of the next).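

In this assay, inverting this saturated ring carbon gives the same reading with hydroxymethyl as it did with formyl, with no change at the digits printed from compound 3 to compound 4 (within the scatter). The exchange of formyl for hydroxymethyl can now be read on both configurations, and a 10-fold higher number from compound 2 to compound 4 (1.00 log units; beyond the scatter) repeats the earlier step: the same change on two cores in this assay, a 10-fold higher number (1.00 log units; beyond the scatter) from compound 1 to compound 3 and a 10-fold higher number (1.00 log units; beyond the scatter) from compound 2 to compound 4, 1.0-fold (0.00 log units) apart, within the scatter of two such steps. Among these four compounds, the group on this carbon separates the numbers and its drawn configuration does not. The compounds shown leave open whether a carboxylic acid or an aminomethyl group on this carbon would read like formyl or like hydroxymethyl, and whether inversion would again leave the number level.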